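A few compounds are considered here, and "the series" means these few. Any claim that something is new, unique, unknown or untested is made for them only; others in the source may bear on it.

Measured compounds:
compound 1 `Brc1ccc(N2C[C@H]3CNC[C@H]3C2)cn1` — 0.28 nM
compound 2 `c1ccc(-c2ccc(N3C[C@H]4CNC[C@H]4C3)nc2)cc1` — > 100000 nM
compound 3 `Cc1ccc(-c2ccc(N3C[C@H]4CN(C)C[C@H]4C3)nn2)cc1` — > 100000 nM

Of the compounds shown here, three have been tested in an assay on membranes from brain for displacement of a labelled ligand from Neuronal acetylcholine receptor; alpha4/beta2 (Rattus norvegicus); a higher number here means a weaker inhibitor, a lower number a stronger inhibitor. Compound 1 gives 0.28 nM. For compound 2 the result is only a limit of the assay, > 100000 nM, and not a number. Compound 3 likewise stands at a limit rather than a number, > 100000 nM. Two of the three values therefore sit at the same boundary, (the limit of > 100000 nM in this assay, at which 2 of the 3 values shown sit), and compound 3 is one of them; nothing further about its potency can be read from what is shown.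

Compound 4 `Cc1cccc(-c2ccc(N3C[C@H]4CN(C)C[C@H]4C3)nn2)c1` is the compound not yet measured. It differs from compound 3 in one change: 3-methylphenyl in place of 4-methylphenyl on an aromatic carbon. Among the measured compounds shown here, no measured pair shows a comparable move, so no step size can be drawn from the data. Since compound 3 is reported only as a limit, the step from compound 3 to compound 4 is expected to be about a number no higher from compound 3 to compound 4 (the limit leaves the size open), with no shift beyond the scatter foreseen. Compound 4 is accordingly expected to give roughly 100000 nM, within a range from 10000 nM to 300000 nM, most likely again reported only as a limit.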

Compound 4, inhibition constant: > 100000 nM
Compound 4 ended at the assay's limit (the forecaster's own chance of this, stated with the estimate: 80%); the middle value sits exactly at the limit.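

Compound 3 and compound 4 both stand at a limit in this assay and not at a number, so no step can be read between them: the limit of > 100000 nM in this assay, at which 3 of the 4 values shown sit. The compounds shown leave open whether 3-methylphenyl in place of 4-methylphenyl changes the result at all.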